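The source may hold more compounds than are shown below. What is called first, only, known or untested is meant among the compounds shown, and "the series" means these compounds.

Measured in a functional assay on NCI-H460 cells (Homo sapiens) for antiproliferative activity, read by MTT assay, with a stated time of 48 h; on this read-out lower numbers stand for stronger inhibition and higher numbers for weaker inhibition:

Compound 1 `CCCCC1(O)C(=O)Nc2ccc(Nc3ccc(F)cc3)cc21`: 32500 nM
Compound 2 `CCCCCC1(O)C(=O)Nc2ccc(Nc3ccc(F)cc3)cc21`: > 100000 nM
Compound 3 `O=C1Nc2ccc(Nc3ccc(F)cc3)cc2C1(O)Cc1ccccc1`: 18100 nM

Compound 2 stands at the limit of > 100000 nM in this assay, at which 1 of the 3 values shown sits, so its entry is a limit and not a number. From the compounds shown here alone, it is the weakest of the three, though how weak remains unknown.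

Compound 4 `CCCCCC1(O)C(=O)Nc2ccc(Nc3ccc(C(F)(F)F)cc3)cc21` keeps the chain of compound 2 and makes one change, trifluoromethyl in place of fluoro on an aromatic carbon. The new group sits on an aromatic carbon of a six-membered aromatic ring of carbon only, para to a large group.

Three measured steps are available: an at least 3.0-fold higher number from compound 1 to compound 2 (0.48 log units; beyond the scatter), a 1.8-fold lower number from compound 1 to compound 3 (0.25 log units; within the scatter) and an at least 5.5-fold lower number from compound 2 to compound 3 (0.74 log units; beyond the scatter). All three alter the group on the saturated chain carbon, and the fluoro stays in place throughout. They show that this assay can respond to a change in that group, but none of them measures a change at the fluoro. These data therefore give no ground for expecting a step beyond the scatter in either direction, and compound 4 is expected to stay close to the limit reached by compound 2.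

The expected step is an at least 1.1-fold lower number from compound 2 to compound 4 (0.04 log units; that floor lies within the scatter). In this assay the estimate for compound 4 is 90000 nM, with an expected range of 30000 nM to 250000 nM.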

Compound 4, half-maximal inhibitory concentration: 16300 nM
The estimate for compound 4 lay 5.5-fold (0.74 log units) above the measured number; measured number outside the range, below it.
By their numbers in this assay, from the lowest: compounds 4, 3 and 1 (each within the scatter of the next). At a limit, above all of these: compound 2.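

In this assay, the change of fluoro to trifluoromethyl on this aromatic carbon, para to a large group, gives an at least 6.1-fold lower number from compound 2 to compound 4 (0.78 log units; beyond the scatter). Within the data shown here, the earlier steps all altered the group on the saturated chain carbon and left the fluoro in place, so this is the first sign that the read-out also responds to a change at this aromatic position, and that a compound with the chain of compound 2 can still give a measurable number. The entry for compound 2 is a limit and not a number, so the step has a floor but no known full size: the limit of > 100000 nM in this assay, at which 1 of the 4 values shown sits.

The compounds shown leave open whether the same change would have a similar effect with the shorter chain of compound 1 or the group of compound 3, since the trifluoromethyl appears here with only one chain. They also leave open how chloro, methoxy or a nitrile on the same aromatic carbon would compare, and so whether this response is particular to trifluoromethyl or shared by other groups at this position.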